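Working notes on a three-membered acrylamide-acid set and one pending analogue

The compounds below may be only part of what the source reports. "The series", "measured", "known", "first", "only" and "open" are said of these compounds alone.

Measured so far in a functional assay on MCF7 cells (Homo sapiens) for inhibition, read by sulforhodamine B assay, with a stated time of 72 h; on this read-out higher numbers stand for weaker inhibition of growth and lower numbers for stronger inhibition of growth:
- compound 1, `O=C(O)/C=C/c1ccncc1-c1ccc2ccccc2c1`: > 10000 nM
- compound 2, `O=C(/C=C/c1ccncc1-c1ccc2cc[nH]c2c1)N1CCOCC1`: > 10000 nM
- compound 3, `O=C(/C=C/c1ccncc1-c1ccc2ccccc2c1)N1CCOCC1`: > 10000 nM

Each of these values is a limit of the assay, not a number. The step that the two limits leave unreadable from compound 3 to compound 1, the change (hydroxy in place of morpholin-4-yl on a carbonyl carbon), is therefore unreadable in size. The difference between the core of compound 2 and the core of compound 3 is not broken down here. Compound 4, `O=C(O)/C=C/c1ccncc1-c1ccc2cc[nH]c2c1`, is not yet measured; it differs from compound 2 by hydroxy in place of morpholin-4-yl on a carbonyl carbon, the same change, at a place described in identical words. Within the data shown here, every value so far sits at the limit, which the limit of > 10000 nM in this assay, at which 3 of the 3 values shown sit, records, so compound 4 is expected to sit there as well, with the step that the limit leaves unreadable from compound 2 to compound 4 estimated as essentially nil. The expected result for compound 4 is 20000 nM, within 5000 nM to 80000 nM.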

Compound 4, concentration for 50% growth inhibition: > 10000 nM
Compound 4: a limit, no number (the forecaster's own chance of this, stated with the estimate: 80%); the middle value is on the limit's open side.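

No new step can be read from compound 2 to compound 4, since both values are limits of the assay, not numbers: the limit of > 10000 nM in this assay, at which 4 of the 4 values shown sit.
The compounds shown leave open what effect hydroxy in place of morpholin-4-yl has on growth inhibition, as none of them gives a readable value.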